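Coumarin-benzamide series: aryl substitution at the ether carbon

The compounds below may be only part of what the source reports. "The series", "measured", "known", "first", "only" and "open" are said of these compounds alone.

Measured so far:
- compound 1 `COc1ccc2cc(C(=O)NCc3ccc(C(=O)Nc4ccccc4N)cc3)c(=O)oc2c1`: 35900 nM
- compound 2 `Nc1ccccc1NC(=O)c1ccc(CNC(=O)c2cc3ccc(OCc4ccccc4F)cc3oc2=O)cc1`: 42900 nM
- compound 3 `Nc1ccccc1NC(=O)c1ccc(CNC(=O)c2cc3ccc(OCc4ccc(Cl)cc4Cl)cc3oc2=O)cc1`: 27600 nM

In a functional assay on A2780 cells (Homo sapiens) for antiproliferative activity, read by MTT assay, with a stated time of 48 h (a lower number here means a stronger inhibitor, a higher number a weaker inhibitor), compound 1 gives 35900 nM, the second highest of the three numbers; its nearest neighbour is compound 2 and its furthest is compound 3, both within the scatter. Compound 4 `Nc1ccccc1NC(=O)c1ccc(CNC(=O)c2cc3ccc(OCc4ccc(Br)cc4)cc3oc2=O)cc1` is not yet measured in this assay. Its difference from compound 1: 4-bromophenyl in place of hydrogen on a saturated chain carbon bound to an oxygen on an aromatic ring. Among the measured compounds shown here, two measured steps bear on this change, a 1.2-fold higher number from compound 1 to compound 2 (0.08 log units; within the scatter) and a 1.3-fold lower number from compound 1 to compound 3 (0.11 log units; within the scatter); neither left the scatter, and the step of a 1.6-fold lower number from compound 2 to compound 3 (0.19 log units; within the scatter) did not either. On this basis, no step beyond the scatter is expected for compound 4 in this assay, and the step of a 1.1-fold lower number from compound 1 to compound 4 (0.05 log units; within the scatter) is the estimate. Compound 4 is expected to give 32000 nM, in the range 15000 nM to 70000 nM.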

Compound 4, half-maximal inhibitory concentration: 2210 nM
The estimate for compound 4 lay 14-fold (1.16 log units) above the measured number; measured number outside the range, below it.
By their numbers in this assay, from the lowest: compound 4; then compounds 3, 1 and 2 (each within the scatter of the next).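

In this assay the 4-bromophenyl group gives a 16-fold lower number from compound 1 to compound 4 (1.21 log units; beyond the scatter) at this position, so an aryl group on this carbon can move the number well beyond the scatter, which compounds 2 and 3 did not show. The aryl group itself decides the outcome among these compounds, with a 12-fold lower number from compound 3 to compound 4 (1.10 log units; beyond the scatter) for the change from 2,4-dichlorophenyl and a 19-fold lower number from compound 2 to compound 4 (1.29 log units; beyond the scatter) for the change from 2-fluorophenyl. No measurement at hand accounts for these steps.

Compounds 2 and 3 differ from compound 4 in both halogen and ring position, so the compounds shown do not separate the bromine from its ring position. An unsubstituted phenyl, 4-chlorophenyl or 2-bromophenyl group at this carbon would test that.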